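A few compounds are considered here, and "the series" means these few. Any claim that something is new, unique, unknown or untested is made for them only; others in the source may bear on it.

Working notes on the series.

The series shares one core with a linking chain to a carboxy-bearing aromatic ring. Compound 1 `Cc1c(OCCCCOc2ccc(C(=O)O)cc2)ccc(C(=O)CC(C)C)c1O` carries an isopropyl on the saturated chain carbon bound to the carbonyl carbon; in an assay on HEK293 cells for positive allosteric modulation of metabotropic glutamate receptor 2 (Rattus norvegicus), read by thallium flux, with a stated time of 2.5 min (a lower number here means a smaller maximal response, a higher number a larger maximal response), compound 1 gives 88%. Compound 2 `Cc1c(OCCCCOc2ccc(C(=O)O)cc2)ccc(C(=O)CC2CCCC2)c1O` carries a cyclopentyl at that place, and in this assay compound 2 gives 82.6%. Compound 3 `CC(=O)c1ccc(OCCCCOc2cccc(C(=O)O)c2C)c(C)c1O` has a different arrangement and in this assay compound 3 gives 79.2%. The one comparable step, a number 5.4 percentage points lower from compound 1 to compound 2 (within the scatter), stays within the scatter, and the values of compound 2 and compound 3 also lie within the scatter of each other, so all three sit together on the numbers shown.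

Compound 4 `Cc1c(OCCCCOc2ccc(C(=O)O)cc2F)ccc(C(=O)CC2CCCC2)c1O` differs from compound 2 by fluoro in place of hydrogen on an aromatic carbon. Within the data shown here, no measured step touches that aromatic ring; the only step in hand, a number 5.4 percentage points lower from compound 1 to compound 2 (within the scatter), concerns the saturated chain carbon and was within the scatter, so it gives no basis for a move in this assay in either direction. Taking compound 2 as the anchor, compound 4 is expected to show a number 0.6 percentage points lower from compound 2 to compound 4 (within the scatter), nothing beyond the scatter. For compound 4 the estimated value in this assay is 82%, with a range from 70% to 94%.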

Compound 4, largest response reached (reported as percent of maximum), in percent of the reference or control that the assay uses: 83.8%
Compound 4: middle estimate off by 1.8 percentage points, on the low side; the measured number falls inside the stated range.
By their numbers in this assay, from the lowest: compounds 3, 2, 4 and 1 (each within the scatter of the next).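

Fluoro in place of hydrogen on the aromatic carbon, ortho to a large group and meta to a carboxy group, is the only single-place change shown on the carboxy-bearing ring. In this assay it gives a number 1.2 percentage points higher from compound 2 to compound 4 (within the scatter), so this position accepts one fluorine atom with no move in the largest response beyond the scatter. Together with a number 5.4 percentage points lower from compound 1 to compound 2 (within the scatter), this means that single changes at two separate places, the saturated chain carbon and this aromatic carbon, both leave the read-out within the scatter. No measurement at hand bears on why the fluoro step is this small.

Open, as far as these compounds go, is whether a chloro, a methoxy or a trifluoromethyl at this same place would also stay within the scatter, and whether fluoro behaves the same with the isopropyl of compound 1 in place of the cyclopentyl. Also open, from the compounds shown here alone, are the effect of a longer linking chain and whether the fluoro changes anything other than the largest response, such as the concentration needed to reach it.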